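The source may report more compounds than this note shows. Statements on the series, on what has been measured and on what is new or still open speak of the compounds shown alone.

Working notes on the series. Going by the values given here, compound 1 `c1ccc2c(c1)CN[C@@H](CN(CC1CCNCC1)[C@H]1CCCc3cccnc31)C2` stands second highest of the three numbers so far in a functional assay on CCRF-CEM cells for antagonist activity at C-X-C chemokine receptor type 4 (Homo sapiens), read by calcium flux, with stated times of 25 min and 90 s (a lower number here means a stronger inhibitor, a higher number a weaker inhibitor), giving 65 nM. Among the compounds with values here, compound 3 `c1cnc2c(c1)CCC[C@@H]2N(CCCN1CCNCC1)Cc1cc2ccccc2cn1` gives 17 nM in this assay, and compound 2 `c1cnc(CN(CCCN2CCNCC2)[C@H]2CCCc3cccnc32)nc1` gives 4320 nM; the only computed step, a 250-fold lower number from compound 2 to compound 3 (2.41 log units; beyond the scatter), exchanges the aromatic group on a saturated chain carbon bound to an amine nitrogen and says nothing about the piperidin-4-yl group of compound 1. Compound 4 `c1ccc2c(c1)CN[C@@H](CN(CCN1CCNCC1)[C@H]1CCCc3cccnc31)C2` is not yet measured. It differs from compound 1 by (piperazin-1-yl)methyl in place of piperidin-4-yl on a saturated chain carbon bound to an amine nitrogen. Within the data shown here, no measured step bears on this exchange, so no step beyond the scatter is expected in this assay. Compound 4 is therefore estimated at about 70 nM, with a range of 25 nM to 200 nM, an expected step of a 1.1-fold higher number from compound 1 to compound 4 (0.03 log units; within the scatter).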

Compound 4, half-maximal inhibitory concentration: 553 nM
The estimate for compound 4 lay 7.9-fold (0.90 log units) below the measured number, and the stated range ends below it.
By their numbers in this assay, from the lowest: compound 3; then compound 1; then compound 4; then compound 2.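

In this assay, going by these compounds alone, the exchange at this position gives an 8.5-fold higher number from compound 1 to compound 4 (0.93 log units; beyond the scatter) on the shared core, the first measured step at a saturated chain carbon bound to an amine nitrogen that concerns the basic-free naming of this side chain rather than the aromatic group. The group here therefore affects the number, with the chain and the ring changing together as (piperidin-4-yl)methyl becomes 2-(piperazin-1-yl)ethyl. Nothing available explains this step. A 2-(piperidin-4-yl)ethyl group would separate the two changes, and the compounds shown leave open which one carries the step.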